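Thiophen-2-yl in place of 2-fluorophenyl

A few compounds are considered here, and "the series" means these few. Any claim that something is new, unique, unknown or untested is made for them only; others in the source may bear on it.

Of the compounds shown here, three sharing one core have been measured in a physicochemical assay for pharmacokinetics; a lower number here means that the compound disappears faster, a higher number that the compound lasts longer. Compound 1 (`O=C(NCc1cccc2ccccc12)N1C(=O)c2ccccc2S1(=O)=O`) gives > 166 h, which is a limit and not a number. Compound 2 (`O=C(NCc1ccccc1F)N1C(=O)c2ccccc2S1(=O)=O`) gives > 166 h, again a limit. Compound 3 (`O=C(NCc1ccc(C(F)(F)F)cc1)N1C(=O)c2ccccc2S1(=O)=O`) gives > 166 h, likewise a limit. Going by the values given here, compound 2 thus stands on a limit alone, and no step between measured compounds can be read from these results.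

Compound 4 (`O=C(NCc1cccs1)N1C(=O)c2ccccc2S1(=O)=O`) carries thiophen-2-yl in place of 2-fluorophenyl on a saturated chain carbon bound to an amide-type nitrogen. Compound 2 sits, with compound 1 and compound 3, at the limit of > 166 h in this assay, at which 3 of the 3 values shown sit, so no change beyond the scatter is expected in this assay. The expected step that the limit leaves unreadable from compound 2 to compound 4 stays within the scatter, with no direction foreseen. A limit rather than a number is the likelier report for the new compound. Compound 4 is estimated at 180 h, with an expected range from 90 h to 360 h.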

Compound 4, half-life: > 166 h
Compound 4: only a limit was reported (the forecaster's own chance of this, stated with the estimate: 80%); the middle value is on the limit's open side.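

Going by these compounds alone, compound 2 and compound 4 both stand on a limit in this assay, so no step between them can be read. The compounds shown leave open how long each one actually lasts, and whether thiophen-2-yl and 2-fluorophenyl differ at all in this read-out.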